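A Fluoro for a Methyl on the Sulfonamide Aryl Group

This account rests on a few compounds, and the source may have more. Where it says the series, first, only, none or still open, it means among the compounds named here.

Of the compounds shown here, three have been measured so far. Compound 3 `CCN(CC)C(=O)CN(c1ccc(C)cc1)S(=O)(=O)c1cccc(C)c1` gives 60 nM in a functional assay on CHO cells for inhibition of Orexin receptor type 2 (Homo sapiens), read by FLIPR and calcium flux; on this read-out lower numbers stand for stronger inhibition and higher numbers for weaker inhibition. Compound 1 `CCN(CC)C(=O)CN(c1cc(C(C)C)ccc1Cl)S(=O)(=O)c1ccc(OC)c(OC)c1` gives 90 nM in this assay, and compound 2 `CCN(CC)C(=O)CN(c1cc(N2CCCC2)ccc1Cl)S(=O)(=O)c1ccc(OC)c(OC)c1` gives 1610 nM. Compound 3 thus holds the lowest of the three numbers, but its gap to compound 1 lies within the scatter, so the two cannot be ordered; only compound 2 stands apart, beyond the scatter from both. Among the measured compounds shown here, the one measured single change, an 18-fold higher number from compound 1 to compound 2 (1.25 log units; beyond the scatter), concerns the pyrrolidin-1-yl in place of isopropyl on an aromatic carbon and lies on a different part of the molecule.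

Compound 4 `CCN(CC)C(=O)CN(c1ccc(C)cc1)S(=O)(=O)c1cccc(F)c1` is the next compound awaiting measurement. It differs from compound 3 by fluoro in place of methyl on an aromatic carbon, that is, 3-methylphenyl to 3-fluorophenyl. For the measured compounds named here, no measured step touches this part of the shared core, so the data offer no direct guide. With one small group exchanged for another of the same size and no change in donors or acceptors, the step is expected to stay within the scatter, as a 1.7-fold higher number from compound 3 to compound 4 (0.22 log units; within the scatter). Compound 4 is therefore estimated at 100 nM, with a range from 30 nM to 330 nM.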

Compound 4, half-maximal inhibitory concentration: 839 nM
For compound 4 the middle estimate is 8.4-fold (0.92 log units) below the measured one, and the stated range ends below it.
By their numbers in this assay, from the lowest: compounds 3 and 1 (each within the scatter of the next); then compounds 4 and 2 (each within the scatter of the next).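

Going from 3-methylphenyl to 3-fluorophenyl gives a 14-fold higher number from compound 3 to compound 4 (1.15 log units; beyond the scatter) in this assay and so shows that this position, which no earlier step touched, responds strongly to an exchange of one heavy atom for one heavy atom, with no change in ring, charge or counted donors and acceptors. Among the compounds shown here, until now the only measured large change was an 18-fold higher number from compound 1 to compound 2 (1.25 log units; beyond the scatter) on a different part of the molecule, where a pyrrolidin-1-yl ring entered in place of isopropyl, so a large step no longer belongs to that part alone, nor to the entry of a larger group. No measurement is at hand that accounts for the size of this step.

As far as these compounds go, it remains open whether the numbers with a hydrogen, chloro, methoxy or an amine on this aromatic carbon would stay close to compound 3 or move towards compound 4, which would show whether methyl is the unusual group here or fluoro. From the compounds shown here alone, it also remains open whether fluoro in place of methyl would give a step of similar size on the core of compound 1.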